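The source may hold more compounds than are shown below. What is called first, only, known or untested is meant among the compounds shown, and "the series" means these compounds.

Within the data shown here, in a functional assay on NCI-H460 cells (Homo sapiens) for cytotoxicity, read by MTT assay, with a stated time of 68 h (on this read-out lower numbers stand for stronger inhibition and higher numbers for weaker inhibition), compound 3 `O=C(Nc1cccc(-c2ccccc2)c1)C(Cl)Cl` gives 20200 nM, the only actual number so far. Compound 1 `O=C(Nc1cccc(-c2ccsc2)c1)C(Cl)Cl` reads > 50000 nM, which is a limit of the assay. Compound 2 `O=C(Nc1cccc(-c2nccs2)c1)C(Cl)Cl` reads > 50000 nM, also a limit. Compound 4 `O=C(Nc1cccc(-c2ccoc2)c1)C(Cl)Cl` carries furan-3-yl in place of phenyl on an aromatic carbon, meta to a ((dichloromethyl)carbonyl)amino group: furan-3-yl in place of phenyl on an aromatic carbon. The relevant measured steps are an at least 2.4-fold lower number from compound 1 to compound 3 (0.39 log units; beyond the scatter) and an at least 2.4-fold lower number from compound 2 to compound 3 (0.39 log units; beyond the scatter), both ending at the phenyl compound. Read in reverse, they point towards a higher number for compound 4 in this assay, so a modest weakening is expected. The expected change is a 2.2-fold higher number from compound 3 to compound 4 (0.35 log units; beyond the scatter). For compound 4 the estimated value is 45000 nM, with an expected range of 20000 nM to 100000 nM.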

Compound 4, half-maximal inhibitory concentration: 37600 nM
Estimate against measurement, compound 4: 1.2-fold (0.08 log units) above; the range from low to high includes it.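

In this assay, a 1.9-fold higher number from compound 3 to compound 4 (0.27 log units; within the scatter), so the separation of phenyl from the thiophen-3-yl and 1,3-thiazol-2-yl groups does not carry over clearly to furan-3-yl. Compound 4 also gives this position a measured number for a five-membered aromatic ring. The steps of an at least 1.3-fold lower number from compound 2 to compound 4 (0.12 log units; that floor lies within the scatter) and an at least 1.3-fold lower number from compound 1 to compound 4 (0.12 log units; that floor lies within the scatter) give only floors, so compound 4 is not separated from either compound, and the bound on both is: the limit of > 50000 nM in this assay, at which 2 of the 4 values shown sit.

On these data alone, whether a carboxylic acid or an aminomethyl group on this aromatic carbon would shift the read-out remains open, as do the actual values behind both limits.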